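Swapping the 4-aminobutyl chain for dimethylcarbamoyl

The compounds below may be only part of what the source reports. "The series", "measured", "known", "first", "only" and "open" are said of these compounds alone.

In a functional assay on A2780 cells (Homo sapiens) for antiproliferative activity (a higher number here means a weaker inhibitor, a lower number a stronger inhibitor), compound 1 (`Cc1ccc2c(c1C)CN(CCCN)CC2c1ccccc1`) gives 2420 nM, compound 2 (`Cc1ccc2c(c1C)CN(CCCCN)CC2c1ccccc1`) gives 2370 nM and compound 3 (`Cc1ccc2c(c1C)CN(CCCN(C)C)CC2c1ccccc1`) gives 3240 nM. Compound 2 therefore sits level with the other two, and the data separate none of the three.

Compound 4 (`Cc1ccc2c(c1C)CN(C(=O)N(C)C)CC2c1ccccc1`) is the next to be considered. It carries dimethylcarbamoyl in place of 4-aminobutyl on an amine nitrogen in a ring.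

For the measured compounds named here, three measured steps bear on this only in part: a 1.0-fold lower number from compound 1 to compound 2 (0.01 log units; within the scatter), a 1.3-fold higher number from compound 1 to compound 3 (0.13 log units; within the scatter) and a 1.4-fold higher number from compound 2 to compound 3 (0.14 log units; within the scatter). All are small, but each alters only the amine end of a chain on the ring nitrogen, and an amine-bearing chain remains throughout. Compound 4 has no such chain, so the change goes beyond anything measured, and the flat steps cannot be carried over with confidence. Going by the values given here, no measured compound shows what removing the chain does.

A move to a higher number is expected, with wide uncertainty in its size. The expected step is a 3.4-fold higher number from compound 2 to compound 4 (0.53 log units; beyond the scatter). Compound 4 is estimated at 8000 nM, with an expected range of 2500 nM to 30000 nM.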

Compound 4, half-maximal inhibitory concentration: 1200 nM
Compound 4: middle estimate off by 6.7-fold (0.82 log units), on the high side; the whole stated range lies above it.
By their numbers in this assay, from the lowest: compounds 4, 2, 1 and 3 (each within the scatter of the next, the first and the last beyond it).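

Removing the amine-bearing chain from the amine nitrogen in a ring costs no activity in this assay. Dimethylcarbamoyl stays within the scatter of the 4-aminobutyl chain (a 2.0-fold lower number from compound 2 to compound 4 (0.30 log units; within the scatter)) and of the 3-aminopropyl chain (a 2.0-fold lower number from compound 1 to compound 4 (0.30 log units; within the scatter)), and only the step from the 3-(dimethylamino)propyl chain passes the scatter, modestly (a 2.7-fold lower number from compound 3 to compound 4 (0.43 log units; beyond the scatter)). Across these four compounds, then, an amine at the end of a chain is not required at this position, which accepts a short group without a hydrogen-bond donor as well as the longer chains, and compound 3 is the only one that dimethylcarbamoyl clearly separates from. Nothing available accounts for this outcome.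

Open, as far as these compounds go, is whether the carbonyl of dimethylcarbamoyl contributes at all, or whether any small group on this nitrogen would serve; acetyl, a plain methyl and the unsubstituted ring amine would separate these readings. For the compounds shown here, also open is how far the tolerance extends, for instance to a pyrrolidine-1-carbonyl group or to a chain ending in a carboxylic acid, since the four compounds cover only one carbamoyl group and three amine chains.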